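A few compounds are considered here, and "the series" means these few. Any claim that something is new, unique, unknown or untested is made for them only; others in the source may bear on it.

Compound 2 `C/C(CC(C)C)=N/Nc1nc(-c2cccc([N+](=O)[O-])c2)cs1` gives 1130000 nM in a functional assay, with a stated time of 90 min; on this read-out lower numbers stand for an effect already at smaller amounts and higher numbers for an effect only at larger amounts of compound. Compound 1 `CCC/C(C)=N\Nc1nc(-c2cccc([N+](=O)[O-])c2)cs1` gives 1200000 nM and compound 3 `CCC/C(CC)=N\Nc1nc(-c2cccc([N+](=O)[O-])c2)cs1` gives 1250000 nM; the steps of a 1.1-fold lower number from compound 1 to compound 2 (0.03 log units; within the scatter) and a 1.1-fold higher number from compound 2 to compound 3 (0.04 log units; within the scatter) leave compound 2 within the scatter of both, so the three numbers sit together. Compound 4 `CCCCCC/C(C)=N\Nc1nc(-c2cccc([N+](=O)[O-])c2)cs1` carries pentyl in place of isopropyl on a saturated chain carbon bound to a carbon with a double bond to nitrogen. The step closest in kind is a 1.0-fold higher number from compound 1 to compound 3 (0.02 log units; within the scatter), which adds chain length at that same place, and a 1.1-fold lower number from compound 1 to compound 2 (0.03 log units; within the scatter) shows a shift in branching of the chain also within the scatter. No step beyond the scatter is therefore expected in this assay for compound 4, with a 1.0-fold higher number from compound 2 to compound 4 (0.01 log units; within the scatter) as the estimated step. Compound 4 is estimated at 1150000 nM, within 500000 nM to 2600000 nM.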

Compound 4, half-maximal effective concentration: 1240000 nM
Compound 4: the middle estimate sits 1.1-fold (0.03 log units) below what was measured; the measured number falls inside the stated range.
By their numbers in this assay, from the lowest: compounds 2, 1, 4 and 3 (each within the scatter of the next).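

In this assay, pentyl in place of isopropyl on a saturated chain carbon bound to a carbon with a double bond to nitrogen gives a 1.1-fold higher number from compound 2 to compound 4 (0.04 log units; within the scatter), and propyl in place of hydrogen on a saturated chain carbon, three bonds along the chain from that carbon, gives a 1.0-fold higher number from compound 1 to compound 4 (0.01 log units; within the scatter). This position thus takes the hexyl chain, the longest shown, with no step beyond the scatter. No evidence bears on this result.

Open, on these data alone, is whether an amine or a carboxylic acid on this chain would give a step beyond the scatter. As far as these compounds go, the shared core is the same throughout, so the effect of a change there also stays open.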